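A few compounds are considered here, and "the series" means these few. Any claim that something is new, unique, unknown or untested is made for them only; others in the source may bear on it.

Working notes on a small set of four compounds, three of them measured. Compound 1 `O=C(O)/C=C/C(=O)c1ccccc1` gives 1.94 in a physicochemical assay for lipophilicity; on this read-out higher numbers stand for higher lipophilicity and lower numbers for lower lipophilicity. Compound 2 `COC(=O)/C=C/C(=O)c1ccc(C)cc1` gives 2.74 in this assay. Compound 3 `COC(=O)/C=C\C(=O)c1ccccc1` gives 1.49 in this assay, the lowest of the three numbers; compound 1 stands nearest, higher by an amount beyond the scatter, and compound 2 furthest, also beyond the scatter. Compound 4 `COC(=O)/C=C/C(=O)c1ccccc1` is not yet measured. From compound 3 to compound 4 (the two compounds have the same atoms and bonds and differ only in configuration as drawn: 1 of 1 stereo elements differ; a double bond is drawn Z in compound 3 and E in compound 4). Going by the values given here, no step between measured compounds shows this change alone. Because compound 1 gives 1.94 and compound 2 gives 2.74, both with the double bond drawn E, compound 4 is expected to give 2.3, between 1.9 and 2.7. This estimate means an upward step of a number 0.81 log units higher from compound 3 to compound 4 (beyond the scatter), expected to lie beyond the scatter.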

Compound 4, partition coefficient: 2.24
Compound 4: the middle estimate sits 0.06 log units above what was measured; the range from low to high includes it.
By their numbers in this assay, from the lowest: compound 3; then compounds 1 and 4 (each within the scatter of the next); then compound 2.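

The double bond configuration alone carries a step in this assay, a number 0.75 log units higher from compound 3 to compound 4 (beyond the scatter), and no other structural difference is available to account for it: the fact that compounds 3 and 4 differ only in the configuration as drawn. Hydrogen in place of methyl on an aromatic carbon can now be read on its own, a number 0.50 log units lower from compound 2 to compound 4 (beyond the scatter). Methyl in place of hydrogen on an oxygen next to a carbonyl group gives a number 0.30 log units higher from compound 1 to compound 4 (within the scatter).

As far as these compounds go, whether the Z to E step keeps its size with methyl on the aromatic carbon or hydrogen on that oxygen remains open. From the compounds shown here alone, a longer chain on that oxygen or an amine on the aromatic carbon also remains open.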